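The source may report more compounds than this note shows. Statements on the series, on what has been measured and on what is new or still open speak of the compounds shown alone.

Among the compounds with values here, in a functional assay on M14 cells (Homo sapiens) for cytotoxicity (on this read-out higher numbers stand for weaker inhibition of growth and lower numbers for stronger inhibition of growth), compound 2 (`CSc1ccc(C2=C(c3ccc(OCC4CO4)cc3)C(=O)N3CCCC3C2)cc1`) gives 90 nM, the lower of the two numbers measured so far. Within the data shown here, the only other measured compound, compound 1 (`CSc1ccc(C2=C(c3ccc(C)c(C)c3)C(=O)N3CCCC3C2)cc1`), gives 800 nM, so compound 2 shows the stronger inhibition of growth, by a margin beyond the usual scatter. The next compound to be tested is compound 3 (`CSc1ccc(C2=C(c3ccc(SC)cc3)C(=O)N3CCCC3C2)cc1`), which has methylsulfanyl in place of the (oxiran-2-yl)methoxy of compound 2 on an aromatic carbon (methylsulfanyl in place of (oxiran-2-yl)methoxy on an aromatic carbon). Among the measured compounds shown here, no step between measured compounds isolates this change, so there is no direct precedent for its size. The expectation rests only on the spread between the two measured compounds. Compound 2 at 90 nM marks the low end of that short series, and compound 1 at 800 nM marks the high end, so a moderate rise in this assay seems more likely than a further fall. The expected change is a 3.3-fold higher number from compound 2 to compound 3 (0.52 log units; beyond the scatter), toward weaker inhibition of growth and probably just beyond the scatter. Compound 3 is expected to read about 300 nM, with an estimated range from 80 nM to 1000 nM.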

Compound 3, concentration for 50% growth inhibition: 5000 nM
Beside the measured number, compound 3's estimate is 17-fold (1.22 log units) below it; measured number outside the range, above it.
By their numbers in this assay, from the lowest: compound 2; then compound 1; then compound 3.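

In this assay, methylsulfanyl in place of (oxiran-2-yl)methoxy on an aromatic carbon, para to a large group, gives a 56-fold higher number from compound 2 to compound 3 (1.74 log units; beyond the scatter) and so shows that the group at this position can shift the read-out by more than the gap between the two earlier compounds. The step of 4-(methylsulfanyl)phenyl in place of 3,4-dimethylphenyl on a double-bonded ring carbon gives a 6.3-fold higher number from compound 1 to compound 3 (0.80 log units; beyond the scatter) and makes compound 3 the weakest inhibitor of growth of the three, with both of its steps beyond the scatter. Nothing shown here accounts for the size of either step.

The compounds shown leave open whether the low number of compound 2 depends on the three-membered ring or on the oxygen that joins the chain to the aromatic carbon, a question that a plain methoxy group or a longer chain such as propoxy on the same carbon would bear on. They also leave open how an amine or a carboxylic acid would read at this position.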